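Does piperidin-1-yl restore activity to compound 2?

This account rests on a few compounds, and the source may have more. Where it says the series, first, only, none or still open, it means among the compounds named here.

- Compound 1 `CN1CCN(CCCn2c(N)c(-c3nc4ccccc4[nH]3)c3nc(C#N)c(C#N)nc32)CC1` gives 3320 nM
- Compound 2 `CCCCn1c(N)c(-c2nc3ccccc3[nH]2)c2nc(C#N)c(C#N)nc21` gives > 50000 nM (a limit)

In a functional assay on HL60/MX2 cells (Homo sapiens) for antiproliferative activity, read by MTT assay, with a stated time of 48 h (a higher number here means a weaker inhibitor, a lower number a stronger inhibitor), compound 2 stands at > 50000 nM as a limit of the assay and not a number. Compound 3 `N#Cc1nc2c(-c3nc4ccccc4[nH]3)c(N)n(CCCN3CCCCC3)c2nc1C#N` keeps the core of compound 2 and differs only in its side chain. The change is piperidin-1-yl in place of methyl on a saturated chain carbon, three bonds along the chain from an aromatic nitrogen in which piperidin-1-yl stands in place of methyl on a saturated chain carbon, three bonds along the chain from an aromatic nitrogen, so that butyl becomes 3-(piperidin-1-yl)propyl.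

Going by the values given here, only one measured step bears on this change: an at least 15-fold higher number from compound 1 to compound 2 (1.17 log units; beyond the scatter) and that step is large. Read in reverse, it suggests that a ring group at this carbon could bring a large fall in the number in this assay as well. Still, piperidin-1-yl is not 4-methylpiperazin-1-yl, and one pair is thin support. The expected change is an at least 14-fold lower number from compound 2 to compound 3 (1.15 log units; beyond the scatter) toward stronger inhibition. The value expected for compound 3 is 3500 nM (estimated range 900 nM to 15000 nM).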

Compound 3, half-maximal inhibitory concentration: 1010 nM
Compound 3: the middle estimate sits 3.5-fold (0.54 log units) above what was measured, within the range that was stated.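

In this assay, the step of an at least 49-fold lower number from compound 2 to compound 3 (1.69 log units; beyond the scatter) shows that the large change seen earlier is not tied to 4-methylpiperazin-1-yl alone: a second ring group on this saturated chain carbon, piperidin-1-yl, also brings the number down strongly. Compound 2 carries a limit of the assay and not a number, so this step gives only a minimum size and its true size stays unknown: the limit of > 50000 nM in this assay, at which 1 of the 3 values shown sits.

The two ring groups are also not interchangeable at this position, as the step of a 3.3-fold lower number from compound 1 to compound 3 (0.52 log units; beyond the scatter) lies beyond the scatter, so the choice of ring group changes the result as well as its presence.

These compounds cannot show whether the ring itself or its nitrogen goes with the lower numbers, since both ring groups contain the ring and at least one nitrogen; a cyclohexyl group, which has a ring and no nitrogen, and an open-chain dimethylamino group, which has a nitrogen and no ring, would pull those two apart. Also open, from the compounds shown here alone, is how morpholin-4-yl would compare on the same chain, and whether a longer chain linking the ring group to the core would keep the effect.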